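Aryl swap on a triazole sulfonamide: predicting compound 4

A few compounds are considered here, and "the series" means these few. Any claim that something is new, unique, unknown or untested is made for them only; others in the source may bear on it.

Measured compounds in a functional assay on HepG2 cells (Homo sapiens) for antiproliferative activity, read by MTT assay, with a stated time of 24 h; a higher number here means a weaker inhibitor, a lower number a stronger inhibitor:
- Compound 1, `Cc1cccc(-n2cc(-c3cccc(NS(=O)(=O)c4c[nH]c(=O)[nH]c4=O)c3)nn2)c1`, gives 7050 nM.
- Compound 2, `O=c1[nH]cc(S(=O)(=O)Nc2cccc(-c3cn(-c4ccccc4F)nn3)c2)c(=O)[nH]1`, gives 13900 nM.
- Compound 3, `Cc1cccc(-n2cc(-c3ccc(NS(=O)(=O)c4c[nH]c(=O)[nH]c4=O)cc3)nn2)c1`, gives only a limit of the assay, > 20000 nM.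

Compounds 1 and 2 share a core and differ only in the aryl group on the aromatic nitrogen; the step of a 2.0-fold higher number from compound 1 to compound 2 (0.29 log units; within the scatter) shows that exchanging these aryl groups left the read-out essentially unchanged. Compound 3 carries the same 3-methylphenyl as compound 1 but is joined to the core differently, and in this assay it stands at the limit of > 20000 nM in this assay, at which 1 of the 3 values shown sits, so no number is available for it, only a limit.

Compound 4, `O=c1[nH]cc(S(=O)(=O)Nc2ccc(-c3cn(-c4ccccc4Cl)nn3)cc2)c(=O)[nH]1`, is the partner of compound 3 with a different aryl group: 2-chlorophenyl in place of 3-methylphenyl on an aromatic nitrogen. Going by the values given here, the one measured step that bears on an aryl exchange of this kind, a 2.0-fold higher number from compound 1 to compound 2 (0.29 log units; within the scatter), was within the scatter, so no move beyond the scatter is expected here either, in either direction. Because compound 3 sits at the limit > 20000 nM, compound 4 is expected to remain at or near that limit, and its estimated step is a step that the limit leaves unreadable from compound 3 to compound 4. The estimate for compound 4 is therefore 30000 nM, in a range from 10000 nM to 100000 nM.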

Compound 4, half-maximal inhibitory concentration: 2230 nM
Compound 4: middle estimate off by 13-fold (1.13 log units), on the high side; measured number below the stated range.
By their numbers in this assay, from the lowest: compound 4; then compounds 1 and 2 (each within the scatter of the next). At a limit, above all of these: compound 3.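

In this assay, exchanging 3-methylphenyl for 2-chlorophenyl on the aromatic nitrogen gives an at least 8.9-fold lower number from compound 3 to compound 4 (0.95 log units; beyond the scatter), so a change of aryl group at this position can move the read-out beyond the scatter. The earlier exchange gave only a 2.0-fold higher number from compound 1 to compound 2 (0.29 log units; within the scatter), which involved a different incoming group on a core joined differently, so these compounds show that a small result for one aryl exchange does not carry over to every aryl exchange at this position. Compound 3 has only a limit and not a number, so the new step gives a minimum size and its true size cannot be read: the limit of > 20000 nM in this assay, at which 1 of the 4 values shown sits.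

The compounds shown do not separate the contribution of the chlorine from that of its place on the aryl ring, and they do not show how 2-chlorophenyl would read on the core of compound 1. Going by these compounds, it also remains open how this position would respond to a phenyl ring carrying an amine or a carboxylic acid, or to a longer chain in place of the aryl group.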